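Acetylated and free glycoside amides: cytotoxicity working notes

The compounds below may be only part of what the source reports. "The series", "measured", "known", "first", "only" and "open" are said of these compounds alone.

Measured in a functional assay on MDA-MB-231 cells (Homo sapiens) for cytotoxicity, read by MTT assay, with a stated time of 24 h; on this read-out higher numbers stand for weaker inhibition and lower numbers for stronger inhibition:
- compound 1, `CCCCCCCCCCCC(=O)Nc1nnc(S[C@@H]2O[C@H](COC(C)=O)[C@H](OC(C)=O)[C@H](OC(C)=O)[C@H]2OC(C)=O)s1`: 26700 nM
- compound 2, `CCCCCCCC/C=C\CCCCCCCCCCCC(=O)Nc1nnc(S[C@@H]2O[C@H](COC(C)=O)[C@H](OC(C)=O)[C@H](OC(C)=O)[C@H]2OC(C)=O)s1`: 25300 nM
- compound 3, `CCCCCCCC/C=C\CCCCCCCCCCCC(=O)Nc1nnc(S[C@@H]2O[C@H](CO)[C@H](O)[C@H](O)[C@H]2O)s1`: 70400 nM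

Compound 1 and compound 2 share the acetylated core and differ only in the chain: hydrogen in place of dec-1-en-1-yl on a saturated chain carbon, ten or more bonds along the chain from a carbonyl carbon. The step in this assay is a 1.1-fold higher number from compound 2 to compound 1 (0.02 log units; within the scatter), so the two chain lengths give numbers that cannot be told apart here.

Compound 3 carries the longer chain on the free, deacetylated core. How compound 3 differs from compound 2 is not broken down here. Compound 3 gives the highest number of the three; against compound 1 and compound 2 the gap is beyond the scatter in both cases, so in this assay the free core with the long chain inhibits less strongly than either acetylated compound.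

Compound 4, `CCCCCCCCCCCC(=O)Nc1nnc(S[C@@H]2O[C@H](CO)[C@H](O)[C@H](O)[C@H]2O)s1`, is the free-core partner of compound 1 and has not been measured. It differs from compound 3 by hydrogen in place of dec-1-en-1-yl on a saturated chain carbon, ten or more bonds along the chain from a carbonyl carbon, which is the same change as from compound 2 to compound 1. Because that change gave a 1.1-fold higher number from compound 2 to compound 1 (0.02 log units; within the scatter), the step from compound 3 to compound 4 is expected to be small, estimated as a 1.0-fold higher number from compound 3 to compound 4 (0.01 log units; within the scatter). Compound 4 is therefore estimated at 72000 nM, with a range of 36000 nM to 145000 nM; the rest is to be filled in when the measurement is known.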

Compound 4, half-maximal inhibitory concentration: 32000 nM
Compound 4: the middle estimate sits 2.3-fold (0.35 log units) above what was measured; measured number outside the range, below it.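

In this assay, the same chain change gives different readings on the two cores: on the acetylated core, the step is a 1.1-fold higher number from compound 2 to compound 1 (0.02 log units; within the scatter), while on the free core, it is a 2.2-fold lower number from compound 3 to compound 4 (0.34 log units; beyond the scatter). Set side by side, the two steps cannot be told apart, even though only the second lies beyond the scatter on its own: the same change on two cores in this assay, a 1.1-fold higher number (0.02 log units; within the scatter) from compound 2 to compound 1 and a 2.2-fold lower number (0.34 log units; beyond the scatter) from compound 3 to compound 4, 2.3-fold (0.37 log units) apart, within the scatter of two such steps This shows that the small step on the acetylated core does not rule out a real drop on the free core, and it does not establish that the change acts differently on the two cores, since each core supplies a single pair and the gap between the steps stays within what repeated measurements could produce.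

The compounds shown cover only the chain bearing dec-1-en-1-yl and the chain with hydrogen in its place, so it remains open how a shorter chain, a longer chain, or a chain ending in an amine or a carboxylic acid would read on either core. Further pairs of that kind on both the acetylated and free cores would be needed to tell whether the step from the chain change truly depends on the core.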